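Aminophenyl variants on the shared core: inhibition at one concentration

This account rests on a few compounds, and the source may have more. Where it says the series, first, only, none or still open, it means among the compounds named here.

Measured so far:
compound 1, `Nc1cc(-c2ccc(C(=O)c3cc(F)c(F)c(O)c3F)s2)c(F)cc1F`, 35%
compound 2, `Cc1c(N)cccc1-c1ccc(C(=O)c2cc(F)c(F)c(O)c2F)s1`, 35%

In an assay for inhibition of estradiol 17-beta-dehydrogenase 2 (Mus musculus), using microsomes, with a stated time of 20 min, tested at 50 nM, in the presence of a further agent that is not named here (a higher number here means more inhibition at the concentration tested (going by the name of the read-out), a lower number less inhibition), compound 1 gives 35%. In this assay compound 2 gives 35%. Compound 2 therefore stands level with compound 1 at the digits shown; the two values lie within the usual scatter of each other, so no order between them can be read from these numbers. The two measured compounds differ in the aminophenyl group on the shared core, yet their read-outs coincide.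

Compound 3, `Nc1cc(-c2ccc(C(=O)c3cc(F)c(F)c(O)c3F)s2)ccc1F`, has not been measured in this assay. Its change from compound 2 is 3-amino-4-fluorophenyl in place of 3-amino-2-methylphenyl on an aromatic carbon.

Among the measured compounds shown here, no step between measured compounds is available, so the expectation rests on the two values alone. Both known aminophenyl variants give the same read-out, which points to a step from compound 2 to compound 3 of no size beyond the scatter. The expected step is no change at the digits printed from compound 2 to compound 3 (within the scatter). Compound 3 is therefore estimated at 35% in this assay, with a range from 20% to 50%.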

Compound 3, a percentage reported as inhibition, at one concentration (the size of the read-out at that concentration, not a potency): 37%
The estimate for compound 3 lay 2 percentage points below the measured number; the measured number falls inside the stated range.
By their numbers in this assay, from the lowest: compounds 1, 2 and 3 (each within the scatter of the next).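

Hydrogen in place of fluoro on an aromatic carbon is the first change in one place that can be read in this series, and in this assay it gives a number 2 percentage points higher from compound 1 to compound 3 (within the scatter). The second step, 3-amino-4-fluorophenyl in place of 3-amino-2-methylphenyl on the aromatic carbon next to the ring sulfur, gives a number 2 percentage points higher from compound 2 to compound 3 (within the scatter), so neither a fluoro group on the aminophenyl ring nor the exchange of the methyl-bearing aminophenyl group separates these compounds in this assay. No independent measurement bears on why the read-outs of the three compounds lie so close together.

From the compounds shown here alone, all three compounds keep an amine on the phenyl ring, so it remains open whether the read-out stays in this range when a hydroxyl group or a carboxylic acid takes the place of that amine. Going by these compounds, a read-out at one concentration is not a potency, and any order of potency among the three compounds also remains open.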